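Benzylamino in Place of Piperidin-1-yl: an Expected Gain

The source may report more compounds than this note shows. Statements on the series, on what has been measured and on what is new or still open speak of the compounds shown alone.

Compound 1 `CCCNc1cc(-c2ccccc2)nc2cc(OC)cc(OC)c12`: 5210 nM
Compound 2 `COc1cc(OC)c2c(-n3ccnc3)cc(-c3ccccc3)nc2c1`: 58600 nM
Compound 3 `COc1cc(OC)c2c(N3CCCCC3)cc(-c3ccccc3)nc2c1`: > 100000 nM (a limit)

In a functional assay on HepG2 cells (Homo sapiens) for inhibition, read by MTT assay, with a stated time of 72 h (on this read-out higher numbers stand for weaker inhibition and lower numbers for stronger inhibition), compound 1 gives 5210 nM and compound 2 gives 58600 nM. Compound 3 sits at the limit of > 100000 nM in this assay, at which 1 of the 3 values shown sits, so only a limit is known for it. The steps of an 11-fold higher number from compound 1 to compound 2 (1.05 log units; beyond the scatter) and an at least 19-fold higher number from compound 1 to compound 3 (1.28 log units; beyond the scatter) are both large, whereas the step of an at least 1.7-fold higher number from compound 2 to compound 3 (0.23 log units; that floor lies within the scatter) has a floor within the scatter. Compound 4 `COc1cc(OC)c2c(NCc3ccccc3)cc(-c3ccccc3)nc2c1` differs from compound 3 by benzylamino in place of piperidin-1-yl on an aromatic carbon. Its benzylamino group, like the propylamino of compound 1, carries one hydrogen-bond donor, which compound 2 and compound 3 lack. The reverse of the large step from compound 1 to compound 3 is therefore expected. Compound 4 is estimated at 9000 nM, between 2500 nM and 40000 nM, an expected step of an at least 11-fold lower number from compound 3 to compound 4 (1.04 log units; beyond the scatter).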

Compound 4, half-maximal inhibitory concentration: 10900 nM
Beside the measured number, compound 4's estimate is 1.2-fold (0.08 log units) below it; measured number inside the range.
By their numbers in this assay, from the lowest: compound 1; then compound 4; then compound 2. At a limit, above all of these: compound 3.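

The benzylamino group of compound 4 gives a clearly lower number than piperidin-1-yl (an at least 9.1-fold lower number from compound 3 to compound 4 (0.96 log units; beyond the scatter)) and than 1H-imidazol-1-yl (a 5.4-fold lower number from compound 2 to compound 4 (0.73 log units; beyond the scatter)), so among these four compounds the two groups carrying a hydrogen-bond donor give the lower numbers. The first of these steps is only a floor, since compound 3 stands at a limit: the limit of > 100000 nM in this assay, at which 1 of the 4 values shown sits. Phenyl in place of ethyl on the chain brings only a modest change (a 2.1-fold higher number from compound 1 to compound 4 (0.32 log units; beyond the scatter)). As far as these compounds go, how a plain amino group or a dimethylamino group would read at this position remains open, so the donor's part cannot be separated from that of the rest of each group.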